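The compounds below may be only part of what the source reports. "The series", "measured", "known", "first", "only" and "open" are said of these compounds alone.

Compound 1, `O=C(/C=C\c1ccc(F)cc1)N1N=C(c2ccncc2)OC1c1c[nH]c2ccccc12`, gives > 30 ug/mL in an ADME assay on PANC-1 cells (Homo sapiens) for cytotoxicity, read by MTT assay, with a stated time of 48 h (a higher number here means a weaker inhibitor of growth, a lower number a stronger inhibitor of growth), which is a limit of the assay rather than a number.
Compound 2, `O=C(/C=C\c1ccccc1Cl)N1N=C(c2ccncc2)OC1c1c[nH]c2ccccc12`, gives > 30 ug/mL in this assay, again a limit and not a number.

Compound 2 therefore stands at the edge of what the assay can report: the limit of > 30 ug/mL in this assay, at which 2 of the 2 values shown sit, describes where both values sit. Among the measured compounds shown here, the only step between measured compounds, a step that the two limits leave unreadable from compound 1 to compound 2, cannot be read, so it gives no size and no direction.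

Compound 3, `O=C(/C=C\c1ccc(Cl)cc1Cl)N1N=C(c2ccncc2)OC1c1c[nH]c2ccccc12`, differs from compound 2 by chloro in place of hydrogen on an aromatic carbon. For the measured compounds named here, no measured step speaks to this change, and the one step available is unreadable, so no shift beyond the scatter can be expected in either direction. Compound 3 is expected to give about 30 ug/mL in this assay, within a range from 8 ug/mL to 100 ug/mL. The step from compound 2 is thus estimated as a number no higher from compound 2 to compound 3 (the limit leaves the size open), most likely appearing again as a limit.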

Compound 3, concentration for 50% growth inhibition: > 30 ug/mL
Compound 3: no number, only a limit; the forecaster's own chance of this, stated with the estimate: 70%; the middle value sits exactly at the limit.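

Compound 3 also gives only a limit and not a number, so its steps from compound 1 and compound 2 cannot be read: the limit of > 30 ug/mL in this assay, at which 3 of the 3 values shown sit.

The compounds shown leave open whether changing the groups on the phenyl ring shifts growth inhibition at all.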